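This account rests on a few compounds, and the source may have more. Where it says the series, first, only, none or still open, it means among the compounds named here.

Measured so far in an ADME assay on microsomes from liver (Mus musculus) for metabolic stability, read by LC-MS, using NADPH, with stated times of 10 min and 30 min; on this read-out lower numbers stand for slow clearance and higher numbers for fast clearance
Compound 1 `CC(=O)N[C@@H]1CCCc2c1cncc2N1C(=O)c2ccc(Cl)cc2[C@@H]1C` gives < 20.2 mL/min/kg as a limit of the assay
Compound 2 `CCS(=O)(=O)N[C@@H]1CCCc2c1cncc2N1Cc2cc(Cl)ccc2C1=O` gives 27 mL/min/kg as a number

Within the data shown here, compound 2 holds the only true number so far, and the other value is a limit. Compound 3 `CC(=O)N[C@@H]1CCCc2c1cncc2N1Cc2cc(Cl)ccc2C1=O` has acetyl in place of ethylsulfonyl on an amine nitrogen. Among the measured compounds shown here, no measured pair shows this change. Compound 1 also bears acetyl on an amine nitrogen, and its < 20.2 mL/min/kg is a limit. The expected step of a 1.2-fold lower number from compound 2 to compound 3 (0.09 log units; within the scatter) is none beyond the scatter in this assay and no direction is firm. Compound 3 is estimated at 22 mL/min/kg (range 15 mL/min/kg to 40 mL/min/kg).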

Compound 3, clearance: < 20.2 mL/min/kg
Compound 3: a limit, no number (the forecaster's own chance of this, stated with the estimate: 40%); at least 1.0-fold (0.03 log units) between middle value and limit.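

In this assay, among these compounds, acetyl in place of ethylsulfonyl on an amine nitrogen gives the first reading of this change at this place: an at least 1.3-fold lower number from compound 2 to compound 3 (0.12 log units; that floor lies within the scatter). Compound 3 gives a limit, not a number, so the full size of the step stays unread: the limit of < 20.2 mL/min/kg in this assay, at which 2 of the 3 values shown sit. The step for hydrogen in place of methyl on a saturated ring carbon cannot be read, since compound 1 and compound 3 both give limits. Open, on these data alone, is how a free amine, a methylsulfonyl group or a longer acyl chain on this nitrogen would read in this assay.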